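Tolylpiperazine in place of the benzimidazolone in compound 1

This account rests on a few compounds, and the source may have more. Where it says the series, first, only, none or still open, it means among the compounds named here.

For the measured compounds named here, compound 1 `O=C(NCCCCN1CCN(c2cccc3[nH]c(=O)[nH]c23)CC1)c1ccc2ccccc2c1` gives 158 nM in an assay on isolated protein for displacement of a labelled ligand from Alpha-1A adrenergic receptor (Homo sapiens) (a lower number here means a stronger inhibitor, a higher number a weaker inhibitor), the lower of the two numbers so far; compound 2 `COc1ccccc1N1CCN(CCCCNC(=O)CC(C)C)CC1` gives 418 nM in this assay, a higher number, beyond the scatter. Compound 3 `Cc1ccccc1N1CCN(CCCCNC(=O)c2ccc3ccccc3c2)CC1` carries the change (a group of 7 heavy atoms (7 carbon; one six-membered aromatic ring of carbon only) in place of a group of 10 heavy atoms (7 carbon, 2 nitrogen, 1 oxygen; one five-membered aromatic ring with 2 hetero atoms, one six-membered aromatic ring of carbon only), on an amine nitrogen in a ring). Going by the values given here, no measured pair shows this change, so its step cannot be read from the series. Compound 3 is expected to lose a little: the step of a 1.8-fold higher number from compound 1 to compound 3 (0.25 log units; within the scatter) is expected to be small, at the edge of the scatter. Compound 3 is estimated at 280 nM in this assay, within 70 nM to 1100 nM.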

Compound 3, inhibition constant: 29.9 nM
The estimate for compound 3 lay 9.4-fold (0.97 log units) above the measured number; measured number outside the range, below it.
By their numbers in this assay, from the lowest: compound 3; then compound 1; then compound 2.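

On the amine nitrogen in the ring, 2-methylphenyl in place of the larger group of compound 1 gives a 5.3-fold lower number from compound 1 to compound 3 (0.72 log units; beyond the scatter) in this assay. The position therefore accepts a group with no hydrogen-bond donors or acceptors, and the donors and acceptor of the group that leaves are not needed for a lower number in this pair. Nothing shown explains the size of this step.

Still open, going by these compounds, is what the methyl contributes, which a plain phenyl or a 2-chlorophenyl on the same nitrogen would address. On these data alone, whether the step carries over to another amide, such as a benzamide, also remains open.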